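The source may hold more compounds than are shown below. What is called first, only, known or untested is meant among the compounds shown, and "the series" means these compounds.

Measured so far in an ADME assay on Nthy-ori 3-1 cells (Homo sapiens) for cytotoxicity, read by MTT assay, with a stated time of 10 days; a higher number here means a weaker inhibitor of growth, a lower number a stronger inhibitor of growth:

compound 1, `Nc1ncnc2c1c(-c1cc(C3CC3)on1)nn2C1CCCCC1`: 32500 nM
compound 2, `CCc1cc(-c2nn(C(C)C)c3ncnc(N)c23)no1`: 28600 nM
compound 3, `CC(C)n1nc(/C=N/OCc2ccccc2)c2c(N)ncnc21`: 9850 nM

Compound 1 gives the highest of the three numbers in this assay. Its nearest neighbour is compound 2, whose number lies within the usual scatter of it, so the two cannot be told apart. Compound 3 stands clearly lower, beyond the scatter, and is therefore the stronger inhibitor of growth of the pair.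

Compound 4, `Nc1ncnc2c1c(-c1cc(C3CC3)on1)nn2C1CCOCC1`, is not yet measured. It differs from compound 1 in one place: oxan-4-yl in place of cyclohexyl on an aromatic nitrogen. Among the measured compounds shown here, no measured pair shows this change directly, so there is no step to borrow from. With nothing in the data pointing either way, the expectation is a step no larger than the scatter, if anything toward a slightly higher number in this assay.

For compound 4 the expected value is 38000 nM, with a range from 15000 nM to 95000 nM. That estimate means an expected step of a 1.2-fold higher number from compound 1 to compound 4 (0.07 log units; within the scatter), which stays within the scatter.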

Compound 4, concentration for 50% growth inhibition: 32900 nM
Compound 4: middle estimate off by 1.2-fold (0.06 log units), on the high side; the range from low to high includes it.
By their numbers in this assay, from the lowest: compound 3; then compounds 2, 1 and 4 (each within the scatter of the next).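

Among the compounds shown here, this is the first direct comparison at the group on the aromatic nitrogen of the shared core. With everything else held the same, oxan-4-yl in place of cyclohexyl gives a 1.0-fold higher number from compound 1 to compound 4 (0.01 log units; within the scatter) in this assay, so compound 1 and compound 4 cannot be told apart. Replacing one ring carbon with oxygen, which adds a hydrogen-bond acceptor to this ring, therefore makes no difference that these numbers can show, and nothing at hand offers an explanation for that.

Compound 2 and compound 3 carry another group on this nitrogen but also differ elsewhere, so they cannot settle how much this position matters. From the compounds shown here alone, what a ring holding an amine, such as piperidin-4-yl, or a carboxylic acid on the oxan-4-yl ring would do here remains open.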